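Notes on the pyridin-2-yl to pyridazin-3-yl swap

This account rests on a few compounds, and the source may have more. Where it says the series, first, only, none or still open, it means among the compounds named here.

In an ADME assay on microsomes from liver (Homo sapiens) for metabolic stability, with a stated time of 10 min (on this read-out lower numbers stand for a less stable compound and higher numbers for a more stable compound), compound 1 `CNC(=O)c1nnc(NC(=O)C2CC2)cc1Nc1cccc(-c2cnccn2)c1OC` gives 58%, compound 2 `CNC(=O)c1nnc(NC(=O)C2CC2)cc1Nc1cccc(-c2cnc(C(C)(C)O)cn2)c1OC` gives 95% and compound 3 `CNC(=O)c1nnc(NC(=O)C2CC2)cc1Nc1cccc(-c2ccccn2)c1OC` gives 79%. Compound 3 is therefore second highest of the three, with its gaps to both neighbours beyond the scatter.

The next structure, compound 4 `CNC(=O)c1nnc(NC(=O)C2CC2)cc1Nc1cccc(-c2cccnn2)c1OC`, carries pyridazin-3-yl in place of pyridin-2-yl, on an aromatic carbon ortho to a methoxy group: pyridazin-3-yl in place of pyridin-2-yl on an aromatic carbon.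

The most relevant measured change is a number 21 percentage points higher from compound 1 to compound 3 (beyond the scatter), a modest step that also exchanges pyrazin-2-yl and pyridin-2-yl. Read in reverse, it points to a lower number for compound 4, although pyridazin-3-yl is not the same ring as pyrazin-2-yl, so it serves only as a partial guide. The other two steps, the large a number 37 percentage points higher from compound 1 to compound 2 (beyond the scatter) and the modest a number 16 percentage points lower from compound 2 to compound 3 (beyond the scatter), both involve 1-hydroxy-1-methylethyl, which compound 4 lacks, so they bear on it little. For the measured compounds named here, no pyridazin-3-yl compound has been measured yet.

The expected change is small and toward a lower number, probably within the scatter: a number 9 percentage points lower from compound 3 to compound 4 (within the scatter). For compound 4 the estimated value is 70%, with an expected range of 52% to 88%.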

Compound 4, percent of the compound remaining: 60%
For compound 4 the middle estimate is 10 percentage points above the measured one; the range from low to high includes it.
By their numbers in this assay, from the lowest: compounds 1 and 4 (each within the scatter of the next); then compound 3; then compound 2.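

In this assay, the swap to pyridazin-3-yl on the aromatic carbon ortho to a methoxy group gives a number 19 percentage points lower from compound 3 to compound 4 (beyond the scatter) and so adds a second ring with 2 hetero atoms that falls short of pyridin-2-yl with its 1 hetero atom. The two unsubstituted rings with 2 hetero atoms are not told apart here, at a number 2 percentage points higher from compound 1 to compound 4 (within the scatter) so a change in where the second ring nitrogen sits has no visible effect between these two, while the count of hetero atoms alone does not hold as a pattern: compound 2 goes against it, its substituted ring also having 2 hetero atoms, with a number 35 percentage points lower from compound 2 to compound 4 (beyond the scatter) as the size of the gap. Nothing available explains why the second ring nitrogen lowers the number in compound 4.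

Still open, from the compounds shown here alone, is whether 1-hydroxy-1-methylethyl on pyridazin-3-yl or on pyridin-2-yl would raise the number as it does on pyrazin-2-yl. Also open, going by these compounds, is whether that lift belongs to the tertiary alcohol itself or would also come with a different group on the ring, such as a primary amine or a carboxylic acid.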